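Shortening the amine chain on a shared triazolopyrimidine-like core

The source may hold more compounds than are shown below. What is called first, only, known or untested is meant among the compounds shown, and "the series" means these compounds.

Compound 1 `CCCCCCNc1nc(-c2ccccc2)nc2c1nnn2Cc1ccccc1` gives 13200000 nM in an assay on isolated protein for binding affinity to adenosine receptor A1 (Bos taurus); on this read-out lower numbers stand for stronger inhibition and higher numbers for weaker inhibition.
Compound 2 `OCCNc1nc(-c2ccccc2)nc2c1nnn2Cc1ccccc1` gives 38000000 nM in this assay.

Compound 2 has the highest of the two numbers; its nearest neighbour is compound 1. Among the compounds with values here, the one measured step, a 2.9-fold higher number from compound 1 to compound 2 (0.46 log units; beyond the scatter), involves the same position. Compound 3 `CCCNc1nc(-c2ccccc2)nc2c1nnn2Cc1ccccc1` differs from compound 2 by methyl in place of hydroxy on a saturated chain carbon, two bonds along the chain from a nitrogen on an aromatic ring. Removing the hydroxy reverses part of that step, so a modest move back toward the number of compound 1 is expected, because a 2.9-fold higher number from compound 1 to compound 2 (0.46 log units; beyond the scatter) ran the other way. The expected step is a 1.9-fold lower number from compound 2 to compound 3 (0.28 log units; within the scatter). Compound 3 is thus estimated at 20000000 nM, with a range from 8000000 nM to 50000000 nM.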

Compound 3, inhibition constant: 37000000 nM
Estimate against measurement, compound 3: 1.9-fold (0.27 log units) below; the measured number falls inside the stated range.
By their numbers in this assay, from the lowest: compound 1; then compounds 3 and 2 (each within the scatter of the next).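

Exchanging hydroxy for methyl on this saturated chain carbon gives a 1.0-fold lower number from compound 2 to compound 3 (0.01 log units; within the scatter), so in this assay the hydroxy of compound 2 does not account for the gap to compound 1. Shortening the chain alone, from compound 1 to the propylamino of compound 3, gives a 2.8-fold higher number from compound 1 to compound 3 (0.45 log units; beyond the scatter), so among these three compounds the gap follows the chain and not the hydroxy. Nothing shown here gives a reason for this result. Still open, going by these compounds, is how an amine or a carboxylic acid at the chain end would read, and whether a chain longer than that of compound 1 would extend the trend.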